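A few compounds are considered here, and "the series" means these few. Any claim that something is new, unique, unknown or untested is made for them only; others in the source may bear on it.

Compound 3 `Cc1ccnc(/C(N)=N/NC(=S)N2CCCCC2)c1` gives 18900 nM in a functional assay on A-431 cells (Homo sapiens) for cytotoxicity, read by MTT assay, with a stated time of 72 h (a higher number here means a weaker inhibitor, a lower number a stronger inhibitor), the highest of the three numbers measured. Its nearest neighbour is compound 1 `Cc1ccnc(/C(N)=N/NC(=S)N2CCOCC2)c1`, which gives 6800 nM in this assay; compound 2 `N/C(=N\NC(=S)N1CCCC1)c1ccccn1` gives 1700 nM and lies furthest away. For the measured compounds named here, the one step computed among the measured compounds, a 2.8-fold higher number from compound 1 to compound 3 (0.44 log units; beyond the scatter), is a modest one.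

Compound 4 `Cc1ccnc(/C(N)=N/NC(=S)N2CCCC2)c1` differs from compound 3 in a single place: pyrrolidin-1-yl in place of piperidin-1-yl on a thiocarbonyl carbon. Going by the values given here, no measured step matches this exact change, since the only pair differing in one place swaps morpholin-4-yl for piperidin-1-yl. Compound 2 carries the same pyrrolidin-1-yl group as compound 4, but on a core without the methyl, so its value shows only what that pairing gives elsewhere. With compound 3 at the high end and compound 2 at the low end, a downward move of modest size is expected for compound 4, a 3.2-fold lower number from compound 3 to compound 4 (0.50 log units; beyond the scatter). Compound 4 is therefore estimated at 6000 nM in this assay, with a range from 2000 nM to 18000 nM.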

Compound 4, half-maximal inhibitory concentration: 900 nM
Estimate against measurement, compound 4: 6.7-fold (0.82 log units) above; the whole stated range lies above it.
By their numbers in this assay, from the lowest: compounds 4 and 2 (each within the scatter of the next); then compound 1; then compound 3.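

On the thiocarbonyl carbon, the change from a six-membered to a five-membered ring carries far more weight than the earlier morpholin-4-yl to piperidin-1-yl step showed: in this assay, pyrrolidin-1-yl in place of piperidin-1-yl gives (a 21-fold lower number from compound 3 to compound 4 (1.32 log units; beyond the scatter)), and pyrrolidin-1-yl in place of morpholin-4-yl gives (a 7.6-fold lower number from compound 1 to compound 4 (0.88 log units; beyond the scatter)). Among the methyl-bearing compounds 1, 3 and 4, the pyrrolidin-1-yl group therefore gives the lowest number. The methyl on the aromatic carbon, by contrast, gives a step within the scatter (a 1.9-fold lower number from compound 2 to compound 4 (0.28 log units; within the scatter)), so with pyrrolidin-1-yl in place the two cores cannot be told apart.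

Going by these compounds, whether an azetidin-1-yl or a dimethylamino group on the thiocarbonyl carbon would match compound 4 remains open. Nothing available explains why the pyrrolidin-1-yl group has this effect.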